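The compounds below may be only part of what the source reports. "The series", "measured", "known", "first", "only" and "open" are said of these compounds alone.

Compound 1 `O=C(O)c1cccc(-c2ccc(/C=C3\S/C(=N\c4ccccc4)N(c4ccc(Cl)cc4)C3=O)o2)c1`: in an ADME assay on Vero cells (Chlorocebus sabaeus) for cytotoxicity (a lower number here means that less compound is tolerated, a higher number that more compound is tolerated), compound 1 gives > 200000 nM, which is a limit of the assay.
Compound 2 `O=C(O)c1cccc(-c2ccc(/C=C3\S/C(=N\c4ccccc4)N(c4ncccc4F)C3=O)o2)c1`: in this assay compound 2 gives > 200000 nM, likewise a limit.
Compound 3 `O=C(O)c1cccc(-c2ccc(/C=C3\S/C(=N\c4ccccc4)N(c4cccc(F)n4)C3=O)o2)c1`: in this assay compound 3 gives > 200000 nM, again a limit.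

Compound 3 thus stands only at a limit, and the same holds for the two other measured compounds: the limit of > 200000 nM in this assay, at which 3 of the 3 values shown sit. Compound 4 `O=C(O)c1cccc(-c2ccc(/C=C3\S/C(=N\c4ccccc4)N(c4cccnc4Cl)C3=O)o2)c1` differs from compound 3 in one place: 2-chloropyridin-3-yl in place of 6-fluoropyridin-2-yl on an amide-type nitrogen in a ring. For the measured compounds named here, three measured steps touch this position, a step that the two limits leave unreadable from compound 1 to compound 2, a step that the two limits leave unreadable from compound 1 to compound 3 and a step that the two limits leave unreadable from compound 2 to compound 3, none of them readable in size. The measured compounds therefore give no basis for a direction, and the same outcome is expected for compound 4, with an expected step that the limit leaves unreadable from compound 3 to compound 4. Compound 4 is estimated at 250000 nM, between 120000 nM and 500000 nM, most likely reported again only as a limit.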

Compound 4, half-maximal cytotoxic concentration: > 200000 nM
Compound 4 ended at the assay's limit; the forecaster's own chance of this, stated with the estimate: 85%; the middle value does not contradict the limit.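

Compound 4 gives > 200000 nM in this assay as a limit of the assay. Its steps from compound 1, compound 2 and compound 3 therefore cannot be read in size, and neither can any other step: the limit of > 200000 nM in this assay, at which 4 of the 4 values shown sit. In this assay the compounds shown leave open whether the group on the amide-type nitrogen in a ring changes the tolerated concentration at all.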